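Swapping tert-butyl for methyl at the ketone

This account rests on a few compounds, and the source may have more. Where it says the series, first, only, none or still open, it means among the compounds named here.

Measured compounds:
compound 1, `Cc1c(OCCCCOc2ccc(C(=O)CC(C)(C)C)c(O)c2C)cccc1C(=O)O`, 136 nM
compound 2, `CCC(=O)c1ccc(OCCCCOc2ccc(F)c(C(=O)O)c2)c(C)c1O`, 124 nM
compound 3, `CCCC(=O)c1ccc(OCCCCOc2cc(C(=O)O)ccc2OC)c(C)c1O`, 103 nM

Three compounds share a core in which a four-carbon chain links a phenol bearing an aryl ketone to a benzoic acid. In an assay on HEK293 cells for positive allosteric modulation of metabotropic glutamate receptor 2 (Rattus norvegicus), read by thallium flux, with a stated time of 2.5 min (a higher number here means that more compound is needed for the effect, a lower number that less compound is needed), compound 1 gives 136 nM. Compound 2 gives 124 nM and compound 3 gives 103 nM. Compound 1 carries the highest of the three numbers, but its distance to compound 2 and to compound 3 both lie within the scatter of repeated measurements, so the three values cannot be ranked against one another.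

The unmeasured compound 4, `CCC(=O)c1ccc(OCCCCOc2cccc(C(=O)O)c2C)c(C)c1O`, keeps the benzoic acid end of compound 1 unchanged and differs only at the ketone: methyl in place of tert-butyl on a saturated chain carbon bound to a carbonyl carbon. Compound 2 already carries the propanoyl group on the same ketone-bearing ring, and its value sits within the scatter of compound 1, so nothing in these data points to a shift beyond the scatter for this change. The step from compound 1 to compound 4 is therefore expected to be small, a 1.0-fold lower number from compound 1 to compound 4 (0.02 log units; within the scatter). Compound 4 is estimated to give 130 nM in this assay, within a range from 60 nM to 280 nM.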

Compound 4, half-maximal effective concentration: 62 nM
For compound 4 the middle estimate is 2.1-fold (0.32 log units) above the measured one; measured number inside the range.
By their numbers in this assay, from the lowest: compounds 4, 3, 2 and 1 (each within the scatter of the next, the first and the last beyond it).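

In this assay, going by these compounds alone, methyl in place of tert-butyl on a saturated chain carbon bound to a carbonyl carbon is the first change that can be read on its own, and it gives a 2.2-fold lower number from compound 1 to compound 4 (0.34 log units; beyond the scatter) with the rest of the structure held fixed. The three earlier compounds differ in more than one place, so they could not show that this position responds to what it carries, here modestly but beyond the scatter. Nothing available explains this step, so the result stands as an observation without a known cause.

The compounds shown leave open how the number changes across the groups that could stand here, such as isopropyl, a longer chain, a cyclopropyl ring, an amine or a hydroxyl, so one step between tert-butyl and methyl defines no trend. They also leave open whether the same exchange would give a similar step with the fluorine-bearing or methoxy-bearing benzoic acid ends of compound 2 and compound 3, since this single pair shares only one such end.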